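The source may report more compounds than this note shows. Statements on the series, on what has been measured and on what is new or still open speak of the compounds shown alone.

Values in a physicochemical assay for solubility, read by spectrophotometry, in phosphate buffer, with a stated time of 2 h, at pH 7.4 (on this read-out higher numbers stand for higher solubility and lower numbers for lower solubility), for the two measured compounds:
- compound 1 `COc1ccc2[nH]c(C(=O)N3CC(=O)N(Cc4ccccc4)[C@@H](Cc4ccccn4)C3)cc2c1` with > 100000 nM
- compound 2 `COc1ccc2[nH]c(C(=O)N3CC(=O)N(Cc4ccccc4)[C@@H](CN4CC5CCCC5C4)C3)cc2c1` with 20700 nM

The entry for compound 1 is > 100000 nM and is a limit of the assay, not a number. Compound 2 at 20700 nM thus carries the only number shown in this assay so far. Compound 3 `COc1ccc2[nH]c(C(=O)N3CC(=O)N(Cc4ccccc4)[C@@H](CN4CCC5(CCCC5)CC4)C3)cc2c1` alters compound 2 on a saturated chain carbon bound to a saturated ring carbon, as a group of 10 heavy atoms (9 carbon, 1 nitrogen; one five-membered non-aromatic ring of carbon only, one six-membered non-aromatic ring with 1 hetero atom) in place of a group of 8 heavy atoms (7 carbon, 1 nitrogen; one five-membered non-aromatic ring of carbon only, one five-membered non-aromatic ring with 1 hetero atom), on a saturated chain carbon bound to a saturated ring carbon sets out. For the measured compounds named here, the one measured step at that place is an at least 4.8-fold lower number from compound 1 to compound 2 (0.68 log units; beyond the scatter) and it removed a group with a six-membered aromatic ring, which compound 2 and compound 3 do not contain, so it is only a loose guide. Resting on that step alone, a small move to a lower number is expected, hardly beyond the scatter, and the estimated change is a 1.7-fold lower number from compound 2 to compound 3 (0.24 log units; within the scatter) overall. For compound 3 the estimate is 12000 nM with a range from 4000 nM to 35000 nM as the likely span.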

Compound 3, solubility: 5000 nM
Compound 3: middle estimate off by 2.4-fold (0.38 log units), on the high side, and the stated range covers the measured number.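

In this assay, the earlier step replaced a group with a six-membered aromatic ring, whereas here one non-aromatic group replaces another and still gives a 4.1-fold lower number from compound 2 to compound 3 (0.62 log units; beyond the scatter) on the same saturated chain carbon. The hydrogen-bond donor and acceptor counts and the net charge are the same for the two groups, so a shift beyond the scatter at this place does not require a change in any of them. Compared with the group with the aromatic ring, the new group gives an at least 20-fold lower number from compound 1 to compound 3 (1.30 log units; beyond the scatter) as a bound only, its starting entry being a limit of the assay: the limit of > 100000 nM in this assay, at which 1 of the 3 values shown sits.

The compounds shown leave open whether the lower number goes with the larger group or with its six-membered ring; these two change together. A morpholine or an unsubstituted piperidine on this chain carbon would help to separate them.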